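Adding bromine beside the fluorine on the hydrazine-side ring

The source may hold more compounds than are shown below. What is called first, only, known or untested is meant among the compounds shown, and "the series" means these compounds.

Measured compounds:
- Compound 1, `CC(=O)Nc1ccc(S(=O)(=O)NNc2ccc(C#N)cc2)cc1`: 1390 nM
- Compound 2, `CC(=O)Nc1ccc(S(=O)(=O)NNc2ccc(S(N)(=O)=O)cc2)cc1`: 3120 nM
- Compound 3, `CC(=O)Nc1ccc(S(=O)(=O)NNc2ccc(F)cc2)cc1`: 609 nM

In an assay on HeLa cells for inhibition of Indoleamine 2,3-dioxygenase 1 (Homo sapiens), read by spectrophotometry, with a stated time of 24 h (on this read-out higher numbers stand for an effect only at larger amounts of compound and lower numbers for an effect already at smaller amounts), compound 3 gives the lowest number of the three. Its nearest neighbour is compound 1, and the step of a 2.3-fold lower number from compound 1 to compound 3 (0.36 log units; beyond the scatter) is modest; the step of a 5.1-fold lower number from compound 2 to compound 3 (0.71 log units; beyond the scatter) is larger but still modest. Among the measured compounds shown here, both steps swap the single group on the outer ring of the shared core.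

Compound 4, `CC(=O)Nc1ccc(S(=O)(=O)NNc2ccc(F)c(Br)c2)cc1`, keeps everything in compound 3 and adds one atom: bromo in place of hydrogen on an aromatic carbon, ortho to a fluoro group and meta to a large group. For the measured compounds named here, no measured step adds a group while keeping another in place, so none bears on this change directly. The measured steps only show that changes on this ring shift the read-out in this assay by modest amounts in either direction. For compound 4 a step of similar size is therefore expected, with no clear direction, and the estimate a 1.1-fold lower number from compound 3 to compound 4 (0.04 log units; within the scatter) is set close to compound 3. The expected value for compound 4 in this assay is 550 nM, with a range from 200 nM to 1500 nM.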

Compound 4, half-maximal effective concentration: 2490 nM
The estimate for compound 4 lay 4.5-fold (0.66 log units) below the measured number, and the stated range ends below it.
By their numbers in this assay, from the lowest: compound 3; then compounds 1, 4 and 2 (each within the scatter of the next, the first and the last beyond it).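

Among the compounds shown here, until this result, the only changes seen on this ring were swaps of its single group; compound 4 shows that adding a group while the fluoro stays in place also moves the read-out. In this assay, bromo in place of hydrogen, ortho to a fluoro group and meta to a large group, gives a 4.1-fold higher number from compound 3 to compound 4 (0.61 log units; beyond the scatter), so this aromatic carbon is not indifferent to substitution, and one added heavy atom is enough to raise the number beyond the scatter. Nothing available gives a reason for this shift.

A chloro or a methyl group on the same carbon would help show whether the rise is specific to bromo or appears with other groups there. Going by these compounds, it also remains open whether bromo would have the same effect with cyano or sulfamoyl in place of the fluoro.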